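The source may report more compounds than this note shows. Statements on the series, on what has been measured and on what is new or still open speak of the compounds shown alone.

Measured so far:
compound 1, `CC[C@@H](Nc1c(C#N)c(-c2ccc(-c3ccncc3C)cc2)nc2cnccc12)C(N)=O`: 2
compound 2, `CC[C@@H](Nc1c(C#N)c(-c2ccc(-c3ccc(OC)cc3)cc2)nc2cnccc12)C(N)=O`: 2.7

Among the measured compounds shown here, in a physicochemical assay for lipophilicity, read by HPLC, at pH 7.5 (on this read-out higher numbers stand for higher lipophilicity and lower numbers for lower lipophilicity), compound 2 gives the higher of the two numbers; the single measured step, a number 0.70 log units higher from compound 1 to compound 2 (beyond the scatter), is beyond the scatter. Compound 3, `CC[C@@H](Nc1c(C#N)c(-c2ccc(-c3ccccc3COC)cc2)nc2cnccc12)C(N)=O`, is not yet measured; it differs from compound 2 by 2-(methoxymethyl)phenyl in place of 4-methoxyphenyl on an aromatic carbon. For the measured compounds named here, the one measured step concerns a different exchange, a nitrogen-containing aromatic ring for a carbon-only one, so it bears only loosely here. With the ether kept and the methoxy rebuilt as a methoxymethyl, no step beyond the scatter is expected. Compound 3 is estimated at 2.7, range 2.3 to 3.1. The expected step is no change at the digits printed from compound 2 to compound 3 (within the scatter).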

Compound 3, distribution coefficient: 2.6
The estimate for compound 3 lay 0.10 log units above the measured number; measured number inside the range.
By their numbers in this assay, from the lowest: compound 1; then compounds 3 and 2 (each within the scatter of the next).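

At this aromatic carbon, para to a large group, the exchange of 4-methoxyphenyl for 2-(methoxymethyl)phenyl reads in this assay as a number 0.10 log units lower from compound 2 to compound 3 (within the scatter), so these two carbon-only rings are not told apart here. Against 3-methylpyridin-4-yl, the new ring gives a number 0.60 log units higher from compound 1 to compound 3 (beyond the scatter), which shows that the gap first seen as a number 0.70 log units higher from compound 1 to compound 2 (beyond the scatter) is not confined to 4-methoxyphenyl. No measurement at hand addresses the origin of either step. Open, going by these compounds, is how this number would respond to a ring carrying an amine or a carboxylic acid, or a longer ether chain.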